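The compounds below may be only part of what the source reports. "The series", "measured", "known", "first", "only" and "open" are said of these compounds alone.

Compound 1, `CCC(CC)C(=O)Nc1sc2c(c1C#N)CCC(C(C)(C)CC)C2`, gives 181 nM in an assay on CHO cells for inhibition of Glucagon receptor (Homo sapiens); on this read-out lower numbers stand for stronger inhibition and higher numbers for weaker inhibition.
Compound 3, `CCC(CC)C(=O)Nc1sc2c(c1C(N)=O)CCC(C(C)(C)CC)C2`, gives 870 nM in this assay.
Compound 2, `CCC(C)(C)C1CCc2c(sc(NC(=O)c3ccc(Br)cc3)c2C#N)C1`, reaches only an assay limit of > 20000 nM in this assay.

Compound 1 holds the lowest of the two measured numbers, with compound 3 showing a 4.8-fold higher number from compound 1 to compound 3 (0.68 log units; beyond the scatter). Compound 2 sits at the limit, (the limit of > 20000 nM in this assay, at which 1 of the 3 values shown sits). Compound 4, `CCC(CC)C(=O)Nc1sc2c(c1C#N)CCC(N(C)Cc1ccccc1)C2`, differs from compound 1 by benzyl(methyl)amino in place of 1,1-dimethylpropyl on a saturated ring carbon. Neither measured step touches that saturated ring carbon: an at least 110-fold higher number from compound 1 to compound 2 (2.04 log units; beyond the scatter) alters the group on the carbonyl carbon, and a 4.8-fold higher number from compound 1 to compound 3 (0.68 log units; beyond the scatter) alters the group on the aromatic carbon. Both of those steps raised the number, so a higher number is expected here as well, with a wide range in the absence of a direct precedent. Compound 4 is estimated at 1500 nM, between 200 nM and 15000 nM. The expected step is an 8.3-fold higher number from compound 1 to compound 4 (0.92 log units; beyond the scatter).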

Compound 4, half-maximal inhibitory concentration: 3820 nM
Beside the measured number, compound 4's estimate is 2.5-fold (0.41 log units) below it; the range from low to high includes it.
By their numbers in this assay, from the lowest: compound 1; then compound 3; then compound 4. At a limit, above all of these: compound 2.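

Placing benzyl(methyl)amino instead of 1,1-dimethylpropyl on the saturated ring carbon gives a 21-fold higher number from compound 1 to compound 4 (1.32 log units; beyond the scatter), so this position, untouched by the earlier steps, also strongly affects the number. Compound 4 nevertheless keeps a measured value, so the core of compound 1 can carry this larger group with its nitrogen and aromatic ring. Nothing measured here explains the rise. Whether the nitrogen or the benzyl part accounts for it stays open. So does whether a primary amine or a simple methyl on this carbon would bring the number back towards that of compound 1.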